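The source may hold more compounds than are shown below. What is called first, only, known or untested is meant among the compounds shown, and "the series" means these compounds.

Of the compounds shown here, two have so far been tested in an assay on membranes from liver for displacement of a labelled ligand from Glucagon receptor (Mus musculus), read by scintillation counting, with a stated time of 60 min; on this read-out higher numbers stand for weaker inhibition and lower numbers for stronger inhibition. Compound 1, `C[C@H](c1ccc(C(=O)NCCC(=O)O)cc1)N1C(=O)C(c2cccc(OC(F)(F)F)c2)=N[C@]12CC[C@@H](C(C)(C)C)CC2`, gives 1500 nM in this assay. Compound 2, `CC(C)(C)[C@H]1CC[C@]2(CC1)N=C(c1cccc(C(F)(F)F)c1)C(=O)N2Cc1ccc(C(=O)NCCC(=O)O)cc1`, gives 10000 nM in this assay. Of these two numbers, compound 1 carries the lower one, and the gap between the two lies beyond the usual scatter of repeated measurements, so compound 1 is the stronger of the pair on this read-out.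

The next compound, compound 3, `C[C@H](c1ccc(C(=O)NCCC(=O)O)cc1)N1C(=O)C(c2cccc(F)c2)=N[C@]12CC[C@@H](C(C)(C)C)CC2`, has not yet been measured. It differs from compound 1 in one place: fluoro in place of trifluoromethoxy on an aromatic carbon. Within the data shown here, no pair of measured compounds differs from each other in exactly one place, so there is no measured step to lean on; the expectation rests on compound 1 alone and on the size of the group that is removed. A shift toward weaker inhibition, of moderate size, is expected, corresponding to a step of a 2.7-fold higher number from compound 1 to compound 3 (0.43 log units; beyond the scatter). Compound 3 is therefore estimated to give about 4000 nM in this assay, with a plausible range from 1500 nM to 12000 nM.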

Compound 3, half-maximal inhibitory concentration: 4400 nM
For compound 3 the middle estimate is 1.1-fold (0.04 log units) below the measured one; the measured number falls inside the stated range.
By their numbers in this assay, from the lowest: compound 1; then compound 3; then compound 2.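

In this assay, going from 3-(trifluoromethoxy)phenyl to 3-fluorophenyl gives a 2.9-fold higher number from compound 1 to compound 3 (0.47 log units; beyond the scatter), so this place on the aromatic ring responds to the group it carries. Among these compounds, no two earlier compounds differed in only one place, which makes this the first direct reading of a single change. The step is modest: the trifluoromethoxy group, with its 5 heavy atoms, is replaced by a single fluorine, and compound 3 still gives 4400 nM on this read-out, so most of the group's atoms can go without inhibition disappearing.

From the compounds shown here alone, two groups at one place cannot show what sets the size of this step, and it remains open whether a chlorine, a methoxy group, a nitrile or a plain hydrogen here would land nearer compound 1 or nearer compound 3. Nothing measured among these compounds gives a reason for the step.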